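Epoxide opened to allylic alcohol on the diterpene acid

This account rests on a few compounds, and the source may have more. Where it says the series, first, only, none or still open, it means among the compounds named here.

Compound 1 `C=C[C@@]1(C)O[C@H]1C[C@H]1C(=C)CC[C@@H]2[C@]1(C)CCC[C@]2(C)C(=O)O` carries an acid on its core and a three-membered ring on the side chain. In a functional assay on SMMC-7721 cells (Homo sapiens) for cytotoxicity, read by MTT assay, with a stated time of 48 h (on this read-out lower numbers stand for stronger inhibition and higher numbers for weaker inhibition), compound 1 gives only > 40000 nM, which is a limit of the measurement and not a number (the limit of > 40000 nM in this assay, at which 1 of the 3 values shown sits). The two other compounds carry a different core. Compound 2 `C=CC(=C)CC[C@@H]1[C@@]2(C)CCC[C@](C)(COC(=O)/C=C/c3ccc(O)cc3)[C@@H]2CC[C@@]1(C)O` gives 15500 nM in this assay. Compound 3 `C=CC(=C)CC[C@@H]1[C@@]2(C)CCC[C@](C)(COC(=O)/C=C/c3ccc(O)c(OC)c3)[C@@H]2CC[C@@]1(C)O` gives 14100 nM in this assay; the move a 1.1-fold lower number from compound 2 to compound 3 (0.04 log units; within the scatter) changes nothing beyond the scatter. Compound 4 `C=CC(=C)[C@@H](O)C[C@H]1C(=C)CC[C@@H]2[C@]1(C)CCC[C@]2(C)C(=O)O` is to be measured. For the measured compounds named here, it differs from compound 1 thus: a group of 6 heavy atoms (5 carbon, 1 oxygen; no ring) in place of a group of 6 heavy atoms (5 carbon, 1 oxygen; one three-membered non-aromatic ring with 1 hetero atom), on a saturated chain carbon bound to a saturated ring carbon That measured step concerns an aromatic substituent on another core and does not bear on the change from compound 1 to compound 4; no measured pair covers an opened three-membered ring. Compound 1 stands at the limit, so no direction can be read from it. Compound 4 is therefore expected near the same region, with the step of a number no higher from compound 1 to compound 4 (the limit leaves the size open) meaning no clear shift. The estimate for compound 4 in this assay is 40000 nM, with a range from 15000 nM to 100000 nM.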

Compound 4, half-maximal inhibitory concentration: > 40000 nM
Compound 4 was reported as a limit; the forecaster's own chance of this, stated with the estimate: 60%; the middle value lies on the limit itself.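

No new step can be read from compound 1 to compound 4, since each is reported only as a limit and not as a number: the limit of > 40000 nM in this assay, at which 2 of the 4 values shown sit.

Still open, on these data alone, is whether replacing the three-membered ring group with the ring-free group changes activity in this assay at all.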